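Trading an amine for an ether on a shared core

The source may report more compounds than this note shows. Statements on the series, on what has been measured and on what is new or still open speak of the compounds shown alone.

Three compounds share a fused core and are compared in an in vitro assay on 293-EBNA cells for binding affinity to corticotropin-releasing factor receptor 1 (Homo sapiens); on this read-out lower numbers stand for stronger inhibition and higher numbers for weaker inhibition. Compound 1 `CCC(COC)N(C)c1nc(C)nc2c1nnn2-c1ccc(C(C)C)cc1Br` gives 11.2 nM, the highest number of the three. Compound 2 `CCCCN(CC)c1nc(C)nc2c1nnn2-c1ccc(SC)cc1Br` gives 10.6 nM, a value within the scatter of compound 1. Compound 3 `CCCCN(CC)c1nc(C)nc2c1ncn2-c1c(Br)cc(OC)cc1OC` gives 3.5 nM, a lower number beyond the scatter. Compound 4 `CCC(COC)Oc1nc(C)nc2c1nnn2-c1ccc(C(C)C)cc1Br` is not yet measured; it differs from compound 1 in one place: a group of 7 heavy atoms (5 carbon, 2 oxygen; no ring) in place of a group of 8 heavy atoms (6 carbon, 1 nitrogen, 1 oxygen; no ring), on an aromatic carbon. Going by the values given here, no single-point step between measured compounds is available to guide this change. Swapping a nitrogen-linked group for an oxygen-linked group of similar size is expected to weaken binding modestly, a step from compound 1 to compound 4 of a 3.1-fold higher number from compound 1 to compound 4 (0.49 log units; beyond the scatter). Compound 4 is therefore estimated at 35 nM, within a range of 10 nM to 150 nM.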

Compound 4, inhibition constant: 1.9 nM
Compound 4: middle estimate off by 18-fold (1.27 log units), on the high side, outside the stated range (below it).
By their numbers in this assay, from the lowest: compounds 4 and 3 (each within the scatter of the next); then compounds 2 and 1 (each within the scatter of the next).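

At this position on the shared core, a nitrogen link is not needed for binding: placing 1-(methoxymethyl)propoxy on the aromatic carbon next to the ring nitrogen gives a 5.9-fold lower number from compound 1 to compound 4 (0.77 log units; beyond the scatter) in this assay. With the rest of compound 1 unchanged, the oxygen-linked chain does better than the nitrogen-linked group it replaces. No data shown here explain this gain.

As far as these compounds go, whether a sulfur-linked or carbon-linked chain would work at this place remains open. So does whether the same swap would help with the different aryl groups of compound 2 or compound 3.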